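The source may hold more compounds than are shown below. What is called first, only, known or untested is meant among the compounds shown, and "the series" means these compounds.

Measured so far in a functional assay on A-431 cells (Homo sapiens) for inhibition, read by sulforhodamine B assay, with a stated time of 2 days; a lower number here means a stronger inhibitor of growth, a higher number a weaker inhibitor of growth:
compound 1 `CC1=C(C(=O)Nc2ccc(C)cc2)C(c2ccc(O)cc2O)NC(NCc2ccccc2)=N1` — 42700 nM
compound 2 `CC1=C(C(=O)Nc2ccc(C)cc2)C(c2ccc(O)cc2O)NC(Nc2ccc([N+](=O)[O-])cc2Cl)=N1` — 31900 nM
compound 3 `CC1=C(C(=O)Nc2cccc([N+](=O)[O-])c2)C(c2ccc(O)cc2O)NC(NCc2ccccc2)=N1` — 35600 nM

All three numbers sit close together. Compound 1 and compound 2 share a core and differ by 2-chloro-4-nitrophenyl in place of benzyl on an amine nitrogen; the step is a 1.3-fold lower number from compound 1 to compound 2 (0.13 log units; within the scatter). Compound 1 and compound 3 differ by 3-nitrophenyl in place of 4-methylphenyl on an amide-type nitrogen, giving a 1.2-fold lower number from compound 1 to compound 3 (0.08 log units; within the scatter). Going by the values given here, for compound 2 against compound 3 no step is worked out here; their two values simply lie within the usual scatter of each other. Among the compounds with values here, no compound among the three can be called the strongest or the weakest inhibitor of growth on this evidence.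

Compound 4 `CC1=C(C(=O)Nc2cccc([N+](=O)[O-])c2)C(c2ccc(O)cc2O)NC(Nc2ccc([N+](=O)[O-])cc2Cl)=N1` has not been measured in this assay. It differs from compound 3 by 2-chloro-4-nitrophenyl in place of benzyl on an amine nitrogen. This is the same change that turned compound 1 into compound 2: the place line reads identically in both cases, on an amine nitrogen whose other neighbours are a carbon with a double bond to nitrogen. The two cores on which the change is made differ by 3-nitrophenyl in place of 4-methylphenyl on an amide-type nitrogen.

Because the earlier instance gave a 1.3-fold lower number from compound 1 to compound 2 (0.13 log units; within the scatter), a step of similar size is expected here, that is a 1.3-fold lower number from compound 3 to compound 4 (0.10 log units; within the scatter) for compound 4, which stays inside the usual scatter. The estimate for compound 4 in this assay is 28000 nM, with a range of 14000 nM to 56000 nM.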

Compound 4, concentration for 50% growth inhibition: 3940 nM
Estimate against measurement, compound 4: 7.1-fold (0.85 log units) above, and the stated range ends above it.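

In this assay, the step to 2-chloro-4-nitrophenyl from benzyl on the amine nitrogen is, on the core of compound 3, a 9.0-fold lower number from compound 3 to compound 4 (0.96 log units; beyond the scatter), and it does not match its earlier instance: the same change on two cores in this assay, a 1.3-fold lower number (0.13 log units; within the scatter) from compound 1 to compound 2 and a 9.0-fold lower number (0.96 log units; beyond the scatter) from compound 3 to compound 4, 6.8-fold (0.83 log units) apart, beyond the scatter of two such steps. Read the other way, the step to 3-nitrophenyl from 4-methylphenyl on the amide-type nitrogen is an 8.1-fold lower number from compound 2 to compound 4 (0.91 log units; beyond the scatter), and it differs in the same way: the same change on two cores in this assay, a 1.2-fold lower number (0.08 log units; within the scatter) from compound 1 to compound 3 and an 8.1-fold lower number (0.91 log units; beyond the scatter) from compound 2 to compound 4, 6.8-fold (0.83 log units) apart, beyond the scatter of two such steps. Going by these compounds alone, the two changes therefore do not add up in this set: each alone stays within the scatter, while compound 4, the only compound carrying both groups, stands clearly apart, but these four compounds cannot show why this happens or whether either change would behave the same way on any other core.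

From the compounds shown here alone, it remains open which part of the two groups the step depends on, and an unsubstituted phenyl or a phenyl bearing a nitrile on the amine nitrogen, paired with the 3-nitrophenyl amide, would begin to separate the contributions of the chlorine and the nitro group. Going by these compounds, it is also open whether another group on the amide-type nitrogen, such as a phenyl bearing a carboxylic acid, would show the same dependence on the amine substituent.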